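From Methoxy to Isopropyl: One Change, One Expectation

The source may hold more compounds than are shown below. What is called first, only, known or untested is meant among the compounds shown, and "the series" means these compounds.

In an assay on microsomes from intestine for inhibition of acyl-CoA:cholesterol acyltransferase (Oryctolagus cuniculus) (on this read-out higher numbers stand for weaker inhibition and lower numbers for stronger inhibition), three compounds have been measured:
compound 1 `CC(C)c1cccc(C(C)C)c1NC(=O)NCc1ccccc1`: 360 nM
compound 2 `CC(C)c1cccc(C(C)C)c1NC(=O)NCC1(c2ccccc2)CCCCC1`: 21 nM
compound 3 `COc1ccccc1NC(=O)NCC1(c2ccccc2)CCCCC1`: 270 nM

Compound 3 holds the second highest of the three numbers. Its value and that of compound 1 lie within the usual scatter, so no order between them can be read. Compound 2 sits well below both, a gap beyond the scatter.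

Compound 4 `CC(C)c1ccccc1NC(=O)NCC1(c2ccccc2)CCCCC1` arises from compound 3 by one change: isopropyl in place of methoxy on an aromatic carbon. For the measured compounds named here, no measured pair shows this exact step. Still, compound 2, which carries two isopropyl groups on that ring, gives 21 nM, so a downward step is expected in this assay. The step from compound 3 to compound 4 is estimated at a 3.4-fold lower number from compound 3 to compound 4 (0.53 log units; beyond the scatter), beyond the scatter but short of the full distance to compound 2. Compound 4 is therefore expected near 80 nM, within a range from 25 nM to 250 nM.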

Compound 4, half-maximal inhibitory concentration: 390 nM
Compound 4: the middle estimate sits 4.9-fold (0.69 log units) below what was measured, outside the stated range (above it).
By their numbers in this assay, from the lowest: compound 2; then compounds 3, 1 and 4 (each within the scatter of the next).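

In this assay, putting isopropyl in place of methoxy at this ring position gives a 1.4-fold higher number from compound 3 to compound 4 (0.16 log units; within the scatter) and so does not separate the two groups. The low number of compound 2 therefore does not come from a single isopropyl alone: taking away its second isopropyl gives a 19-fold higher number from compound 2 to compound 4 (1.27 log units; beyond the scatter) and shows that the second group matters on this core. Nothing measured here explains this difference.

Still open, from the compounds shown here alone, is whether an amine or a chlorine atom in this place would match methoxy and isopropyl. Also open, going by these compounds, is whether two methoxy groups would bring a similar drop in the number.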